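This account rests on a few compounds, and the source may have more. Where it says the series, first, only, none or still open, it means among the compounds named here.

Compound 1 `Cn1c(=O)c(=O)n(C2CCCC2)c2nc(N/N=C/c3ccc(F)c(Cl)c3)ncc21`: 8550 nM
Compound 2 `Cn1c(=O)c(=O)n(C2CCCC2)c2nc(N/N=C/c3cccs3)ncc21`: 75600 nM
Compound 3 `Cc1cc(C)c(/C=N/Nc2ncc3c(n2)n(C2CCCC2)c(=O)c(=O)n3C)c(C)c1`: 13900 nM

In a functional assay on PC-3 cells (Homo sapiens) for antiproliferative activity, read by MTT assay (on this read-out higher numbers stand for weaker inhibition and lower numbers for stronger inhibition), compound 3 stands second highest of these three numbers: its value and that of compound 1 lie within the scatter of each other (a 1.6-fold higher number from compound 1 to compound 3 (0.21 log units; within the scatter)), whereas compound 2 sits clearly further off (a 5.4-fold lower number from compound 2 to compound 3 (0.74 log units; beyond the scatter)). Compound 4 `Cn1c(=O)c(=O)n(C2CCCC2)c2nc(N/N=C/c3ccccc3F)ncc21` differs from compound 3 in one place: 2-fluorophenyl in place of 2,4,6-trimethylphenyl on a carbon with a double bond to nitrogen. Among the measured compounds shown here, no measured step makes this exact swap. The three exchanges of the group on that carbon, including an 8.8-fold higher number from compound 1 to compound 2 (0.95 log units; beyond the scatter), show that only thiophen-2-yl stood apart, while 3-chloro-4-fluorophenyl and 2,4,6-trimethylphenyl gave numbers within the scatter of each other. A step within the scatter is therefore expected, a 1.4-fold lower number from compound 3 to compound 4 (0.14 log units; within the scatter). Compound 4 is estimated at 10000 nM, between 4000 nM and 30000 nM.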

Compound 4, half-maximal inhibitory concentration: 27600 nM
The estimate for compound 4 lay 2.8-fold (0.44 log units) below the measured number; low and high end bracket the measured number.
By their numbers in this assay, from the lowest: compounds 1, 3 and 4 (each within the scatter of the next, the first and the last beyond it); then compound 2.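

In this assay, the group on the carbon with a double bond to nitrogen now separates one substituted phenyl from another: 2-fluorophenyl gives a step beyond the scatter against 3-chloro-4-fluorophenyl (a 3.2-fold higher number from compound 1 to compound 4 (0.51 log units; beyond the scatter)), whereas the two earlier phenyl groups stayed within it. Against 2,4,6-trimethylphenyl, the step stays within the scatter (a 2.0-fold higher number from compound 3 to compound 4 (0.30 log units; within the scatter)). Thiophen-2-yl still stands apart, even from this new group (a 2.7-fold lower number from compound 2 to compound 4 (0.44 log units; beyond the scatter)).

On these data alone, whether an amine or a carboxylic acid on the phenyl ring would keep or lose this level of inhibition remains open. No available evidence accounts for these differences.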